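The source may report more compounds than this note shows. Statements on the series, on what has been measured and on what is new or still open speak of the compounds shown alone.

Compound 1 `COc1cccc(Cn2cnc3sc(-c4ccncc4)cc3c2=O)c1` is the starting point of this small series. In an assay on isolated protein for inhibition of Rho-associated protein kinase 2 (Homo sapiens), read by radiometric assay and 33P incorporation, with a stated time of 40 min, in the presence of a further agent that is not named here (a higher number here means a weaker inhibitor, a lower number a stronger inhibitor), compound 1 gives 6 nM. Compound 2 `COc1cccc(Cn2cnc3sc(-c4ccnc(F)c4)cc3c2=O)c1` carries a fluoro in place of hydrogen on an aromatic carbon, and in this assay compound 2 gives 83 nM, the step being a 14-fold higher number from compound 1 to compound 2 (1.14 log units; beyond the scatter). Compound 3 `COc1cccc(Cn2cnc3sc(-c4ccnc(N)c4)cc3c2=O)c1` instead carries an amino at that carbon; in this assay compound 3 gives 1 nM, reached by a 6.0-fold lower number from compound 1 to compound 3 (0.78 log units; beyond the scatter) and, measured against compound 2, by an 83-fold lower number from compound 2 to compound 3 (1.92 log units; beyond the scatter). Compound 3 therefore stands at the lowest number of the three, with compound 1 nearest and compound 2 furthest.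

Compound 4 `COc1cccc(Cn2cnc3sc(-c4ccc(N)nc4)cc3c2=O)c1` keeps the same atoms but joins them differently: 6-aminopyridin-3-yl in place of 2-aminopyridin-4-yl on an aromatic carbon. Among the compounds with values here, none of the measured steps moves an amino from one aromatic carbon to another, so they bear on this change only loosely. The two amino-bearing steps show that the amino sits in a sensitive place, and a shift of it is expected to cost some of that advantage; the estimated step is a 12-fold higher number from compound 3 to compound 4 (1.08 log units; beyond the scatter). Compound 4 is therefore expected to give about 12 nM, within a range from 2 nM to 70 nM.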

Compound 4, half-maximal inhibitory concentration: > 10000 nM
Compound 4: a limit, no number; the forecaster's own chance of this, stated with the estimate: 2%; middle value at least 830-fold (2.92 log units) away from the limit.
By their numbers in this assay, from the lowest: compound 3; then compound 1; then compound 2. At a limit, above all of these: compound 4.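

In this assay compound 4 stands at a limit and not at a number: the limit of > 10000 nM in this assay, at which 1 of the 4 values shown sits. Rearranging the same atoms from 2-aminopyridin-4-yl to 6-aminopyridin-3-yl gives an at least 10000-fold higher number from compound 3 to compound 4 (4.00 log units; beyond the scatter), so the advantage seen with the amino in compound 3 does not go with the amino alone but with the way the ring is joined and substituted. The new ring also falls behind the pyridin-4-yl that has no amino, with an at least 1600-fold higher number from compound 1 to compound 4 (3.22 log units; beyond the scatter), and behind the 2-fluoropyridin-4-yl, with an at least 120-fold higher number from compound 2 to compound 4 (2.08 log units; beyond the scatter), so at this position the change costs more than any substitution seen earlier.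

Going by these compounds, what stays open is whether the loss follows the pyridin-3-yl attachment itself or the amino placed on it. A plain pyridin-3-yl at this carbon would separate the two, and a methylamino in place of the amino of compound 3 would test how much that group tolerates.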